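From furan-2-yl to trifluoromethyl at one ring carbon

The compounds below may be only part of what the source reports. "The series", "measured", "known", "first", "only" and "open" are said of these compounds alone.

Compound 1 `O=[N+]([O-])C1=CNc2nc(-c3ccco3)nn2C1c1ccc(O)cc1O`: 119000 nM
Compound 2 `O=[N+]([O-])C1=CNc2nc(-c3ccco3)nn2C1c1ccc(O)c(O)c1O`: 317000 nM

In an ADME assay on MDCK cells (Canis lupus familiaris) for cytotoxicity (on this read-out lower numbers stand for higher toxicity in this test and higher numbers for lower toxicity in this test), compound 2 stands highest of the two measured compounds, with 317000 nM as its value. Compound 3 `O=[N+]([O-])C1=CNc2nc(C(F)(F)F)nn2C1c1ccc(O)c(O)c1O` differs from compound 2 in one place, with trifluoromethyl in place of furan-2-yl on an aromatic carbon as the change. Among the compounds with values here, the only measured step is a 2.7-fold higher number from compound 1 to compound 2 (0.43 log units; beyond the scatter) and it comes from a hydroxy in place of hydrogen elsewhere, so it says little here. Within the data shown here, no measured pair changes this position, so the data give no direction, and no step beyond the scatter is expected in this assay. The estimated step is a 1.1-fold lower number from compound 2 to compound 3 (0.02 log units; within the scatter), with wide uncertainty. For compound 3 the expected value is 300000 nM as a middle estimate. The estimated range for compound 3 runs from 110000 nM to 800000 nM at its ends.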

Compound 3, half-maximal cytotoxic concentration: 373000 nM
For compound 3 the middle estimate is 1.2-fold (0.09 log units) below the measured one, within the range that was stated.
By their numbers in this assay, from the lowest: compound 1; then compounds 2 and 3 (each within the scatter of the next).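

Replacing furan-2-yl with trifluoromethyl on the aromatic carbon between two ring nitrogen atoms gives a 1.2-fold higher number from compound 2 to compound 3 (0.07 log units; within the scatter) in this assay, so this pair cannot be told apart in this test. Within the data shown here, the earlier step concerned only a hydroxy on the other aromatic ring, whereas this one is the first reading at this position: here, a five-membered aromatic ring and a group with no ring give values within the scatter of each other. No measured evidence accounts for this result.

On these data alone, whether the same holds for very different groups at this position, such as an amine, a carboxylic acid or a longer chain, remains open. So does whether this swap would read the same on the core of compound 1, which carries one hydroxy fewer.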